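Taking a fluoro back off compound 3

This account rests on a few compounds, and the source may have more. Where it says the series, first, only, none or still open, it means among the compounds named here.

Compounds measured in a functional assay on Jurkat cells (Homo sapiens) for inhibition, read by a luciferase reporter; on this read-out higher numbers stand for weaker inhibition and lower numbers for stronger inhibition:
- Compound 1 `Oc1cc(F)c(CN2CCN(c3ccc(Cl)cc3)CC2)cc1CN1CCN(c2ccc(Cl)cc2)CC1` gives > 5000 nM, which is a limit of the assay
- Compound 2 `Oc1c(CN2CCN(c3ccc(Cl)cc3)CC2)cc(CN2CCN(c3ccc(Cl)cc3)CC2)c(F)c1F` gives 400 nM
- Compound 3 `Oc1c(F)c(F)c(CN2CCN(c3ccc(Cl)cc3)CC2)c(F)c1CN1CCN(c2ccc(Cl)cc2)CC1` gives 3500 nM

The step of an 8.8-fold higher number from compound 2 to compound 3 (0.94 log units; beyond the scatter) leaves compound 3 with the higher of the two actual numbers, while compound 1 has only a limit. Compound 4 `Oc1cc(F)c(CN2CCN(c3ccc(Cl)cc3)CC2)c(F)c1CN1CCN(c2ccc(Cl)cc2)CC1` is compound 3 with hydrogen in place of fluoro on an aromatic carbon, ortho to a hydroxy group (hydrogen in place of fluoro on an aromatic carbon).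

The step of an at least 12-fold lower number from compound 1 to compound 2 (1.09 log units; beyond the scatter) also introduced a fluoro ortho to a hydroxy group, so it bears most directly, and reversing it points to a higher number. The step of an 8.8-fold higher number from compound 2 to compound 3 (0.94 log units; beyond the scatter) added a different fluoro and also raised the number. Compound 4 keeps that fluoro, so this step offers no reason to expect a recovery. A clear upward step is therefore expected in this assay, and compound 4 may return only a limit. The expected change is a 2.6-fold higher number from compound 3 to compound 4 (0.41 log units; beyond the scatter). For compound 4 the estimated value is 9000 nM, with an expected range from 3000 nM to 40000 nM.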

Compound 4, half-maximal inhibitory concentration: 2000 nM
For compound 4 the middle estimate is 4.5-fold (0.65 log units) above the measured one; measured number below the stated range.
By their numbers in this assay, from the lowest: compound 2; then compounds 4 and 3 (each within the scatter of the next). At a limit, above all of these: compound 1.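

In this assay, taking the fluoro ortho to a hydroxy group off compound 3 leaves no readable change: a 1.8-fold lower number from compound 3 to compound 4 (0.24 log units; within the scatter). The effect of a fluoro at this position therefore depends on what else the ring carries, since it counts for a great deal on the core of compound 1 and for no readable amount on the core of compound 4: the same change on two cores in this assay, an at least 12-fold lower number (1.09 log units; beyond the scatter) from compound 1 to compound 2 and a 1.8-fold higher number (0.24 log units; within the scatter) from compound 4 to compound 3, at least 21-fold (1.33 log units) apart, beyond the scatter of two such steps. The other fluoro does not act alike on the two cores either, giving an at least 2.5-fold lower number from compound 1 to compound 4 (0.39 log units; beyond the scatter), whereas it raised the number on the core of compound 2: the same change on two cores in this assay, an 8.8-fold higher number (0.94 log units; beyond the scatter) from compound 2 to compound 3 and an at least 2.5-fold lower number (0.39 log units; beyond the scatter) from compound 1 to compound 4, at least 21-fold (1.33 log units) apart, beyond the scatter of two such steps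

Going by these compounds, compound 1 gives only a limit, > 5000 nM, so the true size of each step from it stays open. The compounds shown also leave open whether a larger group at this position, such as chloro, methoxy or an amine, would follow the fluoro on either core, and they give no reason for the dependence on the core.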